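A few compounds are considered here, and "the series" means these few. Any claim that something is new, unique, unknown or untested is made for them only; others in the source may bear on it.

Compound 1 `CC1=C(/C=C/C(=O)/C=C/c2ccccc2)C(C)(C)CCC1` is the weaker of the two measured chalcone-type compounds in a functional assay on Hep cells (Homo sapiens) for cytotoxicity, read by sulforhodamine B assay, with a stated time of 48 h (a higher number here means a weaker inhibitor, a lower number a stronger inhibitor), where compound 1 gives 62200 nM. Its companion, compound 2 `CC1=C(/C=C/C(=O)/C=C/c2ccc(C)cc2)C(C)(C)CCC1`, carries a methyl on the aromatic ring, and in this assay compound 2 gives 44100 nM. Going by the values given here, the step from one to the other, a 1.4-fold lower number from compound 1 to compound 2 (0.15 log units; within the scatter), is the only measured step available, and it shows that a small substituent on the aromatic ring left the number essentially unchanged. Compound 3 `CC1=C(/C=C/C(=O)/C=C/c2ccccc2[N+](=O)[O-])C(C)(C)CCC1` is formed from compound 1 by nitro in place of hydrogen on an aromatic carbon. Among the compounds with values here, no measured step bears on a nitro group at this position, so the expectation rests only on the single step involving compound 2, which was within the scatter. Compound 3 is therefore expected to stay close to compound 1, with an estimated step of a 1.2-fold lower number from compound 1 to compound 3 (0.09 log units; within the scatter). Compound 3 is estimated at 50000 nM, within a range from 18000 nM to 140000 nM.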

Compound 3, half-maximal inhibitory concentration: 44900 nM
Compound 3: the middle estimate sits 1.1-fold (0.05 log units) above what was measured, within the range that was stated.
By their numbers in this assay, from the lowest: compounds 2, 3 and 1 (each within the scatter of the next).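

Placed on an aromatic carbon ortho to a large group, nitro brings 3 heavy atoms in place of hydrogen, yet the result is (a 1.4-fold lower number from compound 1 to compound 3 (0.14 log units; within the scatter)) in this assay. The earlier compounds shown here showed only a methyl on the aromatic ring (a 1.4-fold lower number from compound 1 to compound 2 (0.15 log units; within the scatter)), so this result adds a second and different group, at a position ortho to a large group, that also stays within the scatter. No measured evidence is available that would account for this result.

Compounds 1, 2 and 3 leave open whether an amine, a carboxylic acid or a longer chain at this position would give a step beyond the scatter. They also leave open how nitro would read on the other carbons of the aromatic ring, or whether any change to the shared core would matter more.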